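Aryl urea substituent change in a dihydrofolate reductase series

A few compounds are considered here, and "the series" means these few. Any claim that something is new, unique, unknown or untested is made for them only; others in the source may bear on it.

Compound 1 `CC1(C)N=C(N)N=C(N)N1c1cccc(CNC(=O)Nc2cccc(C#N)c2)c1` gives 8.19 in an assay on isolated protein for inhibition of Dihydrofolate reductase (Mus musculus); a lower number here means a less potent compound, a higher number a more potent compound, by a factor of ten per unit of this negative logarithm. Among the compounds with values here, compound 2 `CC1(C)N=C(N)N=C(N)N1c1cccc(CNC(=O)Nc2cccc([N+](=O)[O-])c2)c1` gives 8.1 in this assay; the only measured step, a number 0.09 log units lower from compound 1 to compound 2 (within the scatter), is within the scatter. Within the data shown here, compound 2 thus holds the lowest of the two numbers so far, with compound 1 the nearest, and the two cannot be ordered against each other.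

Compound 3 `CN(C)C(=O)c1cccc(NC(=O)NCc2cccc(N3C(N)=NC(N)=NC3(C)C)c2)c1` remains to be measured in this assay. The change from compound 2 is dimethylcarbamoyl in place of nitro on an aromatic carbon. Among the measured compounds shown here, only one measured step bears on this position at all, a number 0.09 log units lower from compound 1 to compound 2 (within the scatter), and it shows that replacing one small group by another on that aromatic carbon left the number essentially unchanged. For the measured compounds named here, no measured step covers dimethylcarbamoyl, so the larger group is uncharted here. On this basis the expected step of a number 0.20 log units lower from compound 2 to compound 3 (within the scatter) is small, with no change beyond the scatter the most likely outcome and a modest drop not excluded. Compound 3 is therefore estimated at 7.9 in this assay, with a range from 7.3 to 8.5.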

Compound 3, logarithm of the reciprocal of the active concentration, log(1/C): 7.77
For compound 3 the middle estimate is 0.13 log units above the measured one; measured number inside the range.
By their numbers in this assay, from the lowest: compound 3; then compounds 2 and 1 (each within the scatter of the next).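

On this aromatic carbon, meta to a large group, the exchange of groups is no longer without effect: in this assay dimethylcarbamoyl gives a number 0.33 log units lower from compound 2 to compound 3 (beyond the scatter) and a number 0.42 log units lower from compound 1 to compound 3 (beyond the scatter) as modest steps beyond the scatter, while the exchange of cyano for nitro (a number 0.09 log units lower from compound 1 to compound 2 (within the scatter)) stayed within it. With dimethylcarbamoyl, the group entering has 5 heavy atoms against 3 for nitro and 1 hydrogen-bond acceptor against 2, and the number falls only modestly, so this position accepts the larger group at a limited cost in this series. Nothing measured on these compounds accounts for the lower number of compound 3.

The compounds shown leave open whether the lower number goes with the two methyl groups on the amide nitrogen or with the carbonyl-linked group as a whole, a question that an unsubstituted carboxamide, a methyl ester or a carboxylic acid on this carbon would address. Also open, from the compounds shown here alone, is how the number responds to an amine or a longer chain at this position, and whether the modest step seen with dimethylcarbamoyl grows with further added bulk such as a morpholine amide.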